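Series notes: aryl substituent variation on the shared core

The source may report more compounds than this note shows. Statements on the series, on what has been measured and on what is new or still open speak of the compounds shown alone.

Measured compounds:
compound 1, `CC(C)(N)CC(=O)N[C@@H]1CCc2ccccc2N(Cc2ccc(-c3ccccc3-c3nnnn3CC(=O)O)cc2)C1=O`, 1 uM in a functional assay (Pituitary gland cell) with Rattus norvegicus as the target; a higher number here means that more compound is needed for the effect, a lower number that less compound is needed
compound 2, `CC(C)(N)CC(=O)N[C@@H]1CCc2ccccc2N(Cc2ccc(-c3ccccc3C(N)=O)cc2)C1=O`, 0.08 uM in this assay
compound 3, `Cc1ccccc1-c1ccc(CN2C(=O)[C@H](NC(=O)CC(C)(C)N)CCc3ccccc32)cc1`, 1 uM in this assay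

Compound 3 stands level with compound 1, the two together giving the highest numbers of the three; the remaining step is a 13-fold higher number from compound 2 to compound 3 (1.10 log units; beyond the scatter). Compound 4, `Cn1nnc(-c2ccccc2-c2ccc(CN3C(=O)[C@H](NC(=O)CC(C)(C)N)CCc4ccccc43)cc2)n1`, is not yet measured. It differs from compound 3 by 2-methyl-2H-tetrazol-5-yl in place of methyl on an aromatic carbon. For the measured compounds named here, two steps bear on this: no change at the digits printed from compound 1 to compound 3 (within the scatter), where a different tetrazolyl group replaced methyl without effect, and a 13-fold higher number from compound 2 to compound 3 (1.10 log units; beyond the scatter), the only large step, which involves carbamoyl rather than any tetrazole. Since a tetrazole bearing a carboxymethyl group was level with methyl, the step of a 1.7-fold lower number from compound 3 to compound 4 (0.22 log units; within the scatter) is expected to stay within the scatter, perhaps slightly lower. Compound 4 is estimated at 0.6 uM, range 0.15 uM to 2.5 uM.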

Compound 4, concentration for half-maximal effect: 0.3 uM
Compound 4: the middle estimate sits 2.0-fold (0.30 log units) above what was measured; measured number inside the range.
By their numbers in this assay, from the lowest: compound 2; then compound 4; then compounds 1 and 3 (each within the scatter of the next).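

For the compounds shown here, on an aromatic carbon ortho to a large group, 2-methyl-2H-tetrazol-5-yl separates from methyl, with a 3.3-fold lower number from compound 3 to compound 4 (0.52 log units; beyond the scatter) in this assay and the first tetrazole step beyond the scatter. The substituted tetrazole matters, since 1-(carboxymethyl)-1H-tetrazol-5-yl stayed level with methyl and the exchange gives a 3.3-fold lower number from compound 1 to compound 4 (0.52 log units; beyond the scatter) in the same assay. Carbamoyl keeps the lowest number, with a 3.8-fold higher number from compound 2 to compound 4 (0.57 log units; beyond the scatter) on going to the tetrazole.

Nothing available explains these steps. Open, going by these compounds, is how a nitrile, an aminomethyl group or an unsubstituted tetrazole would read at this position.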